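The source may hold more compounds than are shown below. What is called first, only, known or untested is meant among the compounds shown, and "the series" means these compounds.

Measured so far:
compound 1 `CC(=O)N1N=C(c2ccccc2)CC1c1cccc(Cl)c1Cl`: in a functional assay on HEp-2 cells (Homo sapiens) for cytotoxicity, read by sulforhodamine B assay, with a stated time of 48 h (on this read-out higher numbers stand for weaker inhibition and lower numbers for stronger inhibition), compound 1 gives 24000 nM.
compound 2 `COc1cc(C2CC(c3ccc(Br)cc3)=NN2C(C)=O)cc(OC)c1OC`: in this assay compound 2 gives 4530 nM.

Compound 1 has the higher of the two numbers; the number of compound 2 is lower, and the gap between them is beyond the usual scatter. Among the compounds with values here, the two compounds differ in more than one place, so no single step can be drawn between them.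

Compound 3 `CC(=O)N1N=C(c2ccco2)CC1c1cccc(Cl)c1Cl` is not yet measured. It differs from compound 1 by furan-2-yl in place of phenyl on a carbon with a double bond to nitrogen. Within the data shown here, no measured pair carries this change or any other single change, so there is nothing to lean on but the value of compound 1 itself. An exchange of one aromatic ring for another is expected to move the number little, in either direction, and not clearly beyond the scatter. The step of a 1.1-fold lower number from compound 1 to compound 3 (0.04 log units; within the scatter) is expected to be small. The estimate for compound 3 in this assay is 22000 nM, in the range 7000 nM to 70000 nM.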

Compound 3, half-maximal inhibitory concentration: 43200 nM
Beside the measured number, compound 3's estimate is 2.0-fold (0.29 log units) below it; low and high end bracket the measured number.
By their numbers in this assay, from the lowest: compound 2; then compounds 1 and 3 (each within the scatter of the next).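

In this assay, within the data shown here, furan-2-yl in place of phenyl on a carbon with a double bond to nitrogen gives a 1.8-fold higher number from compound 1 to compound 3 (0.26 log units; within the scatter), the first step that can be read at a single place. At this position of the core of compound 1, then, a six-membered aromatic ring of carbon only and a five-membered aromatic ring with one hetero atom and one hydrogen-bond acceptor are not told apart by this read-out. No measurement at hand bears on why this exchange leaves the number within the scatter.

Going by these compounds, whether a non-aromatic group at this carbon, such as a cyclohexyl ring or a short alkyl chain, would stay within the scatter remains open. On these data alone, it is equally open whether a phenyl ring carrying a dimethylamino group or a carboxylic acid would do so.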